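Pendant aryl swap on a biaryl chalcone scaffold

The source may report more compounds than this note shows. Statements on the series, on what has been measured and on what is new or still open speak of the compounds shown alone.

Compound 1 `COc1ccc(/C=C/C(=O)c2ccccc2-c2ccc(OC)c(OC)c2)cc1` and compound 2 `COc1ccc(/C=C/C(=O)c2ccccc2-c2ccc(OC)c(OC)c2)cc1OC` share one core and differ in one place. In a functional assay on MCF7 cells (Homo sapiens) for antiproliferative activity, read by sulforhodamine B assay, with a stated time of 48 h (on this read-out higher numbers stand for weaker inhibition and lower numbers for stronger inhibition), compound 1 gives 1100 nM, while compound 2 gives 4900 nM; the step is a 4.5-fold higher number from compound 1 to compound 2 (0.65 log units; beyond the scatter), so compound 2 holds the highest number of the two measured.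

Compound 3 `COc1ccc(/C=C/C(=O)c2ccccc2-c2ccc(F)cc2)cc1OC` changes the other aryl arm: 4-fluorophenyl in place of 3,4-dimethoxyphenyl on an aromatic carbon. Among the compounds with values here, no measured step covers this kind of change; the only step in hand, from compound 1 to compound 2, concerns a single methoxy on a different ring and was modest, so it gives direction only loosely. Within this assay the change is expected to move the number upward, with wide uncertainty: compound 3 is expected at 8000 nM, between 1500 nM and 40000 nM, an expected step of a 1.6-fold higher number from compound 2 to compound 3 (0.21 log units; within the scatter).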

Compound 3, half-maximal inhibitory concentration: 240 nM
For compound 3 the middle estimate is 33-fold (1.52 log units) above the measured one; the whole stated range lies above it.
By their numbers in this assay, from the lowest: compound 3; then compound 1; then compound 2.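

In this assay the aryl arm on an aromatic carbon ortho to a large group proves far more responsive than the methoxy site probed earlier: 4-fluorophenyl in place of 3,4-dimethoxyphenyl gives a 20-fold lower number from compound 2 to compound 3 (1.31 log units; beyond the scatter) as a large step, against the modest 4.5-fold higher number from compound 1 to compound 2 (0.65 log units; beyond the scatter) on the other ring. The entering group has fewer heavy atoms and fewer hydrogen-bond acceptors than the group it replaces, and this single step cannot separate the fluorine from the loss of the methoxy groups or from these counts. No measurement in hand accounts for the size of the step.

Going by these compounds, whether a plain phenyl, a 4-chlorophenyl or an aminophenyl at this place would give a similar number remains open. Also open, on these data alone, is whether the same swap would behave alike on the core of compound 1, with its single methoxy on the other ring.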